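Phenyl in Place of Thiophen-2-yl: What to Expect

The source may report more compounds than this note shows. Statements on the series, on what has been measured and on what is new or still open speak of the compounds shown alone.

In a functional assay on CCRF-CEM cells (Homo sapiens), read by MTT assay, with a stated time of 72 h (a lower number here means a stronger inhibitor, a higher number a weaker inhibitor), two compounds have been measured so far:

compound 1 `COc1ncnc2c1c(-c1ccoc1)cn2[C@@H]1O[C@H](CO)[C@@H](O)[C@H]1O` gives 110 nM
compound 2 `COc1ncnc2c1c(-c1cccs1)cn2[C@@H]1O[C@H](CO)[C@@H](O)[C@H]1O` gives 90 nM

Compound 2 has the lower of the two numbers, but its nearest neighbour, compound 1, lies within the scatter of it, so the two values cannot be told apart on this evidence. Among the measured compounds shown here, the only step between them, a 1.2-fold lower number from compound 1 to compound 2 (0.09 log units; within the scatter), shows that exchanging one five-membered ring with a single hetero atom for another left the read-out essentially unchanged.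

Compound 3 `COc1ncnc2c1c(-c1ccccc1)cn2[C@@H]1O[C@H](CO)[C@@H](O)[C@H]1O` takes this one move further: phenyl in place of thiophen-2-yl on an aromatic carbon. For the measured compounds named here, no measured step bears directly on a carbocyclic six-membered ring at this position, so the expectation rests on the single step already seen, which was flat. Given that compound 1 sits at 110 nM and compound 2 sits at 90 nM, compound 3 is expected to land close to them, with no step beyond the scatter, the estimated change being a 1.7-fold higher number from compound 2 to compound 3 (0.22 log units; within the scatter). Compound 3 is therefore estimated at 150 nM, with a range from 50 nM to 450 nM.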

Compound 3, half-maximal inhibitory concentration: > 20000 nM
Compound 3 gave a limit, no number; the forecaster's own chance of this, stated with the estimate: 5%; middle value at least 130-fold (2.12 log units) from the limit.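

In this assay compound 3 gives no number, only a limit: the limit of > 20000 nM in this assay, at which 1 of the 3 values shown sits. Even so, this aromatic carbon proves far less tolerant than the earlier pair suggested: phenyl in place of thiophen-2-yl gives an at least 220-fold higher number from compound 2 to compound 3 (2.34 log units; beyond the scatter), and phenyl in place of furan-3-yl gives an at least 180-fold higher number from compound 1 to compound 3 (2.25 log units; beyond the scatter), both large and beyond the scatter. The earlier exchange between the two five-membered aromatic rings with 1 hetero atom, a 1.2-fold lower number from compound 1 to compound 2 (0.09 log units; within the scatter), gave no sign of this, so the flat result holds only for those two groups and does not extend to a six-membered aromatic ring of carbon only.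

Phenyl alters ring size and removes the hetero atom in one move, and the compounds shown do not separate these two changes. From the compounds shown here alone, it remains open whether pyridin-3-yl, a six-membered aromatic ring that keeps a ring nitrogen, would follow phenyl or the two five-membered rings, and whether a methyl group or a thiophen-3-yl ring at this position would keep the values of compound 1 and compound 2.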